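Working notes: methyl on the ring oxygen of compound 2

The source may hold more compounds than are shown below. What is called first, only, known or untested is meant among the compounds shown, and "the series" means these compounds.

Three compounds have numbers in a functional assay on EA.hy 926 cells (Homo sapiens) for cytotoxicity, read by MTT assay, with stated times of 24 h and 12 h, tested at 100 uM; on this read-out higher numbers stand for a stronger effect at the one concentration tested and lower numbers for a weaker effect. Compound 1 `CCOC(=O)/C=C/c1ccc(OC)cc1OC(=O)c1nc(C)c(C)nc1C` gives 39.9% and compound 3 `Cc1nc(C)c(C(=O)Oc2ccc(/C=C/C(=O)O)cc2)nc1C` gives 93.2%. Compound 2 `CCOC(=O)/C=C/c1ccc(OC(=O)c2nc(C)c(C)nc2C)c(O)c1` gives 375%, the highest of the three, and the gap to each of the other two is beyond the scatter of repeated measurements. Among the compounds with values here, no pair of measured compounds differs in only one place, so no measured single step is available to anchor a prediction.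

Compound 4 `CCOC(=O)/C=C/c1ccc(OC(=O)c2nc(C)c(C)nc2C)c(OC)c1` is the unmeasured analogue of compound 2. The change is methyl in place of hydrogen on an oxygen on an aromatic ring; cut one bond further out, it reads hydroxy to methoxy. Compound 1 also carries a methoxy group and gives 39.9%, but it differs from compound 4 in more than one place, so it serves only as a loose pointer. The expected step in this assay is downward and beyond the scatter, estimated as a number 265 percentage points lower from compound 2 to compound 4 (beyond the scatter). Compound 4 is estimated at 110%, within a range from 35% to 320%, the width reflecting that the pointer rests on a single distant compound.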

Compound 4, a percentage reported as activity, at one concentration (the size of the read-out at that concentration, not a potency): 71.6%
For compound 4 the middle estimate is 38.4 percentage points above the measured one, and the stated range covers the measured number.
By their numbers in this assay, from the lowest: compound 1; then compound 4; then compound 3; then compound 2.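

In this assay, within the data shown here, hydroxy to methoxy gives a number 303.4 percentage points lower from compound 2 to compound 4 (beyond the scatter), the first measured single step. The high number of compound 2 is therefore tied, in this pair, to hydrogen rather than methyl on this oxygen on an aromatic ring, and the addition of one carbon removes most of it. No available measurement accounts for the size of this step.

On these data alone, whether the step follows from losing the hydroxy hydrogen or from the added methyl stays open; an amine, a fluorine or a longer ether chain such as ethoxy at this place would help separate the two. A single pair also leaves open whether the same change on another compound of the series gives a step of similar size.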